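Microsomal stability notes: compound 3 to compound 4

The source may report more compounds than this note shows. Statements on the series, on what has been measured and on what is new or still open speak of the compounds shown alone.

Measured in an ADME assay on microsomes from liver (Homo sapiens) for metabolic stability, using NADPH, with a stated time of 30 min, in the presence of a further agent that is not named here; on this read-out lower numbers stand for a less stable compound and higher numbers for a more stable compound:
compound 1, `CC(C)C1Cc2n[nH]cc2CN1S(=O)(=O)c1ccc(Cl)cc1`: 5%
compound 2, `O=S(=O)(c1ccc(Cl)cc1)N1Cc2c[nH]nc2CC1c1cncnc1`: 67%
compound 3, `O=S(=O)(c1ccc(Cl)cc1)N1Cc2c[nH]nc2CC1c1cccc(F)c1`: 14%

Compound 3 holds the second highest of the three numbers. Its nearest neighbour is compound 1, and the step of a number 9 percentage points higher from compound 1 to compound 3 (within the scatter) lies within the scatter, so the two cannot be ordered. Its furthest neighbour is compound 2, and the step of a number 53 percentage points lower from compound 2 to compound 3 (beyond the scatter) is large and beyond the scatter.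

Compound 4, `O=S(=O)(c1ccc(Cl)cc1)N1Cc2c[nH]nc2CC1c1ccc(Cl)cc1`, is not yet measured. It differs from compound 3 in one place: 4-chlorophenyl in place of 3-fluorophenyl on a saturated ring carbon.

Among the measured compounds shown here, no measured step exchanges one halogen-bearing aromatic ring for another. The steps that touch the same saturated ring carbon are a number 62 percentage points higher from compound 1 to compound 2 (beyond the scatter), which is large, and a number 9 percentage points higher from compound 1 to compound 3 (within the scatter), which is within the scatter; neither compares two substituted phenyl groups, so they bear only loosely on the present change. On the numbers shown, the phenyl-bearing compound 3 and the isopropyl-bearing compound 1 sit together at the low end, and the move to another phenyl group gives no grounds to expect a step beyond the scatter in this assay .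

The expected step is a number 2 percentage points lower from compound 3 to compound 4 (within the scatter). Compound 4 is therefore estimated at 12%, with a range from 3% to 30%.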

Compound 4, percent of the compound remaining: 12%
Beside the measured number, compound 4's estimate shows no gap at the digits printed, and the stated range covers the measured number.
By their numbers in this assay, from the lowest: compounds 1, 4 and 3 (each within the scatter of the next); then compound 2.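

In this assay, 4-chlorophenyl in place of 3-fluorophenyl on the saturated ring carbon gives a number 2 percentage points lower from compound 3 to compound 4 (within the scatter), so a change of both the halogen and its place on the phenyl ring does not separate these two compounds. 4-Chlorophenyl in place of pyrimidin-5-yl gives a number 55 percentage points lower from compound 2 to compound 4 (beyond the scatter), while 4-chlorophenyl in place of isopropyl gives a number 7 percentage points higher from compound 1 to compound 4 (within the scatter); the large gap to the pyrimidin-5-yl compound now holds for two halogen-bearing phenyl groups rather than one, and neither of them stands apart from the isopropyl compound. Nothing available explains why the pyrimidin-5-yl compound stands apart from the other three.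

The compounds shown leave open whether the high number in this assay belongs to pyrimidin-5-yl alone or extends to other aromatic rings containing nitrogen, such as pyridin-3-yl, or to a saturated ring such as tetrahydropyran-4-yl. They also leave open how an unsubstituted phenyl group, or a phenyl group carrying a carboxylic acid or an amine, would compare on this ring carbon.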